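A few compounds are considered here, and "the series" means these few. Any claim that something is new, unique, unknown or untested is made for them only; others in the source may bear on it.

Measured in a functional assay on MGC-803 cells (Homo sapiens) for inhibition, read by MTT assay, with a stated time of 72 h; on this read-out higher numbers stand for weaker inhibition and lower numbers for stronger inhibition:
- compound 1 `Cc1cc(Nc2cc(-c3ccccc3)[nH]n2)n2nc(SCC3CCCCC3)nc2n1`: 12600 nM
- compound 2 `CCCCCc1c(C)nc2nc(SCc3ccc(Cl)cc3)nn2c1Nc1cc(-c2ccccc2)[nH]n1`: 7140 nM
- compound 3 `Cc1cc(Nc2ccn(Cc3ccc(F)cc3)n2)n2nc(SCc3ccc(Br)cc3)nc2n1`: 3070 nM

In this assay compound 1 gives 12600 nM, which lies within the scatter of compound 2 at 7140 nM. Compound 3, at 3070 nM, stands lower than compound 1, and that gap is beyond the scatter.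

Compound 4 `C=CCSc1nc2nc(C)cc(Nc3cc(-c4ccccc4)[nH]n3)n2n1`, not yet measured, differs from compound 1 in one place: vinyl in place of cyclohexyl on a saturated chain carbon bound to a sulfur. Cut one bond further out, this reads cyclohexylmethyl to allyl.

Among the measured compounds shown here, no measured pair differs in one place only, so the series gives no direct size for this change. For the measured compounds named here, the only guide is the narrow spread of the measured numbers, from compound 3 at 3070 nM to compound 1 at 12600 nM. A modest move towards a higher number is therefore expected, and it may stay within the scatter. The expected step is a 1.2-fold higher number from compound 1 to compound 4 (0.08 log units; within the scatter). The estimate for compound 4 is 15000 nM, with an expected range from 6000 nM to 40000 nM.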

Compound 4, half-maximal inhibitory concentration: 17200 nM
Beside the measured number, compound 4's estimate is 1.1-fold (0.06 log units) below it, within the range that was stated.
By their numbers in this assay, from the lowest: compound 3; then compounds 2, 1 and 4 (each within the scatter of the next, the first and the last beyond it).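

In this assay, among the compounds shown here, vinyl in place of cyclohexyl on a saturated chain carbon bound to a sulfur gives a 1.4-fold higher number from compound 1 to compound 4 (0.14 log units; within the scatter), the first reading of a single change. Going from cyclohexylmethyl to allyl removes the ring and takes the leaving group's 6 heavy atoms down to 2 in the entering group, yet the two compounds are not separated on this read-out. Nothing available gives a reason for this result.

On these data alone, whether an amine or a carboxylic acid in this place would give a step beyond the scatter stays open. So does whether the same change would keep its size where other parts of the molecule differ, as they do in compound 2 and compound 3.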